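Benzyl for Ethyl on the Piperazine of Compound 2

A few compounds are considered here, and "the series" means these few. Any claim that something is new, unique, unknown or untested is made for them only; others in the source may bear on it.

Measured compounds in a functional assay on MCF7 cells (Homo sapiens) for cytotoxicity, read by MTT assay, with a stated time of 24 h, tested at 32 ug/mL; a lower number here means a weaker effect, a higher number a stronger effect of the compound at the concentration tested:
compound 1, `Cn1c(-c2ccc(NC(=O)CSC3=NCCS3)cc2)nc(-c2ccccc2)c1-c1ccccc1`, gives 52.5%
compound 2, `CCN1CCN(CC(=O)Nc2ccc(-c3nc(-c4ccccc4)c(-c4ccccc4)n3C)cc2)CC1`, gives 38.6%

Two compounds share the core of compound 1 and differ only in the group on the saturated chain carbon bound to the carbonyl carbon. Among the compounds with values here, compound 2 stands at the bottom of these two numbers in this assay: the single measured step, a number 13.9 percentage points lower from compound 1 to compound 2 (beyond the scatter), goes beyond the scatter and is modest in size.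

Compound 3, `Cn1c(-c2ccc(NC(=O)CN3CCN(Cc4ccccc4)CC3)cc2)nc(-c2ccccc2)c1-c1ccccc1`, has not yet been measured. It differs from compound 2 in one place: phenyl in place of methyl on a saturated chain carbon bound to an amine nitrogen in a ring. The only measured step concerns a different position, the exchange of the whole ring group on the chain carbon bound to the carbonyl carbon, so no step shown here bears directly on a change from methyl to phenyl on the saturated chain carbon bound to the amine nitrogen in the ring. With nothing to guide a direction, the expected step of a number 3.4 percentage points higher from compound 2 to compound 3 (within the scatter) is small, likely within the scatter. Compound 3 is therefore estimated at 42%, with a range from 28% to 58%.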

Compound 3, a percentage reported as activity, at one concentration (the size of the read-out at that concentration, not a potency): 33.6%
Compound 3: the middle estimate sits 8.4 percentage points above what was measured; measured number inside the range.
By their numbers in this assay, from the lowest: compounds 3 and 2 (each within the scatter of the next); then compound 1.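

In this assay, within the data shown here, phenyl in place of methyl on a saturated chain carbon bound to an amine nitrogen in a ring gives a number 5 percentage points lower from compound 2 to compound 3 (within the scatter), the first reading at this position. The earlier step, a number 13.9 percentage points lower from compound 1 to compound 2 (beyond the scatter), exchanged the whole ring group on the saturated chain carbon bound to the carbonyl carbon, whereas the ethyl to benzyl exchange keeps that ring group and adds one six-membered aromatic ring of carbon only, without a step beyond the scatter at this single concentration. No measurement is available that would explain this outcome at this position.

What the compounds shown leave open is whether this tolerance extends beyond a plain benzyl, for instance to a longer chain such as phenylpropyl, to a benzyl carrying a carboxylic acid or an amine on its ring, or to a small hydrogen in place of the ethyl. They also leave open whether the same exchange would read alike at other concentrations, since one read-out at one concentration gives no potency for compound 2 or compound 3.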